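A few compounds are considered here, and "the series" means these few. Any claim that something is new, unique, unknown or untested is made for them only; others in the source may bear on it.

Measured in an ADME assay on CHO cells for agonist activity at prostacyclin receptor (Homo sapiens), read by HTRF and cAMP accumulation; a higher number here means that more compound is needed for the effect, a lower number that less compound is needed:

compound 1, `O=C(O)CCC1=CC[C@@H]2[C@@H](/C=C/[C@@H](O)COc3ccccc3)[C@H](O)C[C@@H]2OC1` — > 10000 nM, a limit of the assay
compound 2, `O=C(O)CC[C@@H]1CC[C@@H]2[C@@H](/C=C/[C@@H](O)COc3ccccc3)[C@H](O)C[C@@H]2OC1` — > 10000 nM, a limit of the assay
compound 3, `O=C(O)CC[C@H]1CC[C@@H]2[C@@H](/C=C/[C@@H](O)COc3ccccc3)[C@H](O)C[C@@H]2OC1` — > 10000 nM, a limit of the assay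

Compound 2 stands at the limit in this assay, and no number is known for it. The same holds for compound 1 and for compound 3, so that the limit of > 10000 nM in this assay, at which 3 of the 3 values shown sit, gives no ordering among the three. Compound 2 and compound 3 share every atom and bond and differ only at one stereocentre on a saturated ring carbon (the fact that compounds 2 and 3 differ only in the configuration as drawn); the step that the two limits leave unreadable from compound 2 to compound 3 cannot be read, since both ends sit at the limit.

Compound 4, `O=C(O)CCC[C@@H]1CC[C@@H]2[C@@H](/C=C/[C@@H](O)COc3ccccc3)[C@H](O)C[C@@H]2OC1`, differs from compound 2 by carboxymethyl in place of carboxy on a saturated chain carbon, two bonds along the chain from a saturated ring carbon. Within the data shown here, no measured step bears on this change: the only step among the measured compounds is a change of configuration, and it is unreadable. With every measured value a limit, no size can be assigned to the step in this assay, and any direction is open. Compound 4 is therefore expected to sit near the limit as well, with the step of a number no higher from compound 2 to compound 4 (the limit leaves the size open) estimated at about zero; the estimate for compound 4 is 10000 nM, within 2000 nM to 50000 nM.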

Compound 4, half-maximal effective concentration: > 10000 nM
Compound 4 was reported as a limit; the forecaster's own chance of this, stated with the estimate: 70%; the middle value lies on the limit itself.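

In this assay, among these compounds, compound 4 gives > 10000 nM, a limit of the assay and not a number; compound 2 also sits at a limit, so no step between them can be read. The compounds shown leave open whether any of these changes alters the read-out at all.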